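The source may hold more compounds than are shown below. What is called first, only, known or untested is meant among the compounds shown, and "the series" means these compounds.

Series notes. The shared core of compound 1 `Cc1ccc(C)c(-c2nc(CN3CCC(C(=O)NCCCN4C[C@H](C)C[C@H](C)C4)CC3)c(C)o2)c1` carries a 2,5-dimethylphenyl on the aromatic carbon of its five-membered ring. In an ADME assay on microsomes from liver (Rattus norvegicus) for metabolic stability, read by LC-MS, using NADPH, at 37 degrees C (a higher number here means that the compound lasts longer, a lower number that the compound disappears faster), compound 1 gives 0.5 h. Compound 2 `Cc1ccccc1-c1nc(CN2CCC(C(=O)NCCCCN3C[C@H](C)C[C@H](C)C3)CC2)c(C)o1` differs from compound 1 in the aryl group and in the length of the chain to the dimethylpiperidine, and in this assay compound 2 gives 0.2 h. Among the compounds with values here, on these two numbers compound 1 stands highest, with compound 2 the nearest and beyond the scatter below it; since two changes separate them, the two values show only that both compounds disappear quickly.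

Compound 3 `Cc1oc(-c2c(Cl)cccc2C(F)(F)F)nc1CN1CCC(C(=O)NCCCN2C[C@H](C)C[C@H](C)C2)CC1` is not yet measured in this assay. Its difference from compound 1 is 2-chloro-6-(trifluoromethyl)phenyl in place of 2,5-dimethylphenyl on an aromatic carbon. Within the data shown here, no measured pair isolates this change. The expectation is a modest rise from compound 1 to compound 3, a 1.6-fold higher number from compound 1 to compound 3 (0.20 log units; within the scatter), since the two measured values, compound 1 at 0.5 h and compound 2 at 0.2 h, both lie low and leave room upward. For compound 3 the estimated half-life in this assay is 0.8 h, in the range 0.35 h to 1.8 h.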

Compound 3, half-life: 0.03 h
Compound 3: the middle estimate sits 27-fold (1.43 log units) above what was measured; measured number below the stated range.
By their numbers in this assay, from the lowest: compound 3; then compound 2; then compound 1.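

In this assay, the aryl group on this aromatic carbon of the five-membered ring turns out to matter strongly for the half-life: 2-chloro-6-(trifluoromethyl)phenyl in place of 2,5-dimethylphenyl gives a large step (a 17-fold lower number from compound 1 to compound 3 (1.22 log units; beyond the scatter)) that lies beyond the scatter. This is the only pair shown that differs in one place, so the drop can be assigned to the aryl exchange alone, with the amide chain and the dimethylpiperidine unchanged, whereas compound 1 and compound 2 differ in two places and could assign nothing. Nothing at hand bears on what lies behind the size of this step.

Still open, going by these compounds, is whether the drop follows from the chlorine, the trifluoromethyl or the two together, a question that a plain phenyl, a 2-chlorophenyl and a 2-(trifluoromethyl)phenyl on the same core would separate. Also open, on these data alone, is how far the aryl group and the chain length each contribute to the gap between compound 1 and compound 2, and whether a pyridyl ring at this position would hold or lengthen the half-life.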